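This account rests on a few compounds, and the source may have more. Where it says the series, first, only, none or still open, it means among the compounds named here.

Compound 1 `Nc1ncc(-c2cccc(Cl)c2)c(-c2ccccc2)n1` is one of three close relatives tested in an assay on CHO cells for displacement of a labelled ligand from adenosine receptor A1 (Homo sapiens), read by scintillation counting, with a stated time of 1 h, tested at 1 uM; a higher number here means more inhibition at the concentration tested (going by the name of the read-out), a lower number less inhibition. In this assay compound 1 gives > 80%, a limit of the assay rather than a number. Compound 2 `COc1cccc(-c2cnc(N)nc2-c2ccccc2)c1` gives > 80%, also a limit. Compound 3 `COc1ccc(-c2cnc(N)nc2-c2ccccc2)cc1Cl` gives > 80%, again a limit. Because (the limit of > 80% in this assay, at which 3 of the 3 values shown sit), the steps a step that the two limits leave unreadable from compound 1 to compound 2 and a step that the two limits leave unreadable from compound 1 to compound 3 cannot be read in size, and both alter a different part of compound 1 than the change leading to compound 4 `CC(C)Nc1ncc(-c2cccc(Cl)c2)c(-c2ccccc2)n1`, where (isopropyl in place of hydrogen on a nitrogen on an aromatic ring). Among the measured compounds shown here, no measured step bears directly on this change, so the expected size of a number at least 20 percentage points lower from compound 1 to compound 4 (beyond the scatter) rests on the standing of compound 1 alone and is uncertain in direction. Compound 4 is estimated to give 60%, within 20% to 90%.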

Compound 4, a percentage reported as inhibition, at one concentration (the size of the read-out at that concentration, not a potency): 71%
For compound 4 the middle estimate is 11 percentage points below the measured one, and the stated range covers the measured number.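

Isopropyl on this nitrogen, the change from amino to isopropylamino, gives the first value in this assay that is a number and not a limit: the limit of > 80% in this assay, at which 3 of the 4 values shown sit.

The change amounts to a number at least 9 percentage points lower from compound 1 to compound 4 (that floor lies within the scatter). Inhibition therefore remains substantial with isopropyl in place of hydrogen, but the data do not show whether it truly falls, as compound 1 has only a limit.

As far as these compounds go, how a methyl, a longer butyl chain or an acetyl group on this nitrogen would compare remains open. So does whether isopropyl would act alike with the other ring substituents seen in compound 2 and compound 3.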